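This account rests on a few compounds, and the source may have more. Where it says the series, first, only, none or still open, it means among the compounds named here.

In a functional assay on NCI-H1975 cells (Homo sapiens) for inhibition, read by sulforhodamine B assay, tested at 10 uM (on this read-out lower numbers stand for less inhibition and higher numbers for more inhibition at the one concentration tested (going by the name of the read-out)), compound 2 `CN(C)c1ccc(C2CC(c3ccc(-n4cncn4)cc3)=NN2C(=O)CCCl)cc1` gives -0.7%. Compound 1 `CN1CCN(c2ccc(C3=NN(C(=O)CCCl)C(c4ccc(N(C)C)cc4)C3)cc2)CC1` gives -0.2%; the step of a number 0.5 percentage points lower from compound 1 to compound 2 (within the scatter) leaves compound 2 at the same level as compound 1, both near zero. Compound 3 `CN(C)c1ccc(C2CC(c3ccc(-n4cncn4)cc3)=NN2C(=O)c2cc(Cl)cc(Cl)c2)cc1` differs from compound 2 by 3,5-dichlorophenyl in place of 2-chloroethyl on a carbonyl carbon. Among the measured compounds shown here, no measured step touches the carbonyl carbon, so nothing sets the size of this change; the two measured compounds show only that neither variant with a 2-chloroethyl on the carbonyl carbon inhibits. For compound 3 in this assay the expected value is 5%, with a range of -10% to 25%. The expected step is a number 5.7 percentage points higher from compound 2 to compound 3 (within the scatter), none beyond the scatter.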

Compound 3, a percentage reported as inhibition, at one concentration (the size of the read-out at that concentration, not a potency): 8.4%
Beside the measured number, compound 3's estimate is 3.4 percentage points below it, and the stated range covers the measured number.
By their numbers in this assay, from the lowest: compounds 2, 1 and 3 (each within the scatter of the next).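

Swapping 2-chloroethyl for 3,5-dichlorophenyl gives the first reading at the carbonyl carbon: in this assay the change is a number 9.1 percentage points higher from compound 2 to compound 3 (within the scatter). An aromatic ring of 8 heavy atoms in place of a 3-atom chain therefore leaves the read-out within the scatter at this position. No supporting data bear on this result.

As far as these compounds go, whether an amine, a carboxylic acid or a longer chain on the carbonyl carbon would move the read-out beyond the scatter remains open. Also open, from the compounds shown here alone, is whether 3,5-dichlorophenyl would behave alike alongside 4-methylpiperazin-1-yl.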